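A few compounds are considered here, and "the series" means these few. Any claim that something is new, unique, unknown or untested is made for them only; others in the source may bear on it.

Going by the values given here, in a functional assay on HCT-116 cells (Homo sapiens) for cytotoxicity, read by MTT assay (a higher number here means a weaker inhibitor, a lower number a stronger inhibitor), compound 3 (`Nc1ccccc1NC(=O)c1ccc(CSc2nc3ccccc3[nH]2)cc1`) gives 300 nM and is the lowest of the three numbers so far, ahead of compound 2 (`Nc1ccccc1NC(=O)c1ccc(CSc2ncc[nH]2)cc1`) at 5000 nM and compound 1 (`Nc1ccccc1NC(=O)c1ccc(CSc2nc3ccc(NCc4ccccn4)cc3s2)cc1`) at 1000 nM in this series. Compound 4 (`Nc1ccccc1NC(=O)c1ccc(CSc2nc3ccccc3s2)cc1`) carries 1,3-benzothiazol-2-yl in place of 1H-benzimidazol-2-yl on a sulfur is the whole change. Among the compounds with values here, the one measured step at this sulfur, a 17-fold lower number from compound 2 to compound 3 (1.22 log units; beyond the scatter) in size, is large but exchanges a different pair of groups, so it sets no direct size here. Compound 1 also bears a 1,3-benzothiazol-2-yl group, with an added substituent, and its number stays moderate. Within the data shown here, a small rise is expected in this assay and no large step: the estimate is a 1.7-fold higher number from compound 3 to compound 4 (0.22 log units; within the scatter) as a modest change. Compound 4 is estimated at 500 nM within a range of 180 nM to 1400 nM for now.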

Compound 4, half-maximal inhibitory concentration: 800 nM
For compound 4 the middle estimate is 1.6-fold (0.20 log units) below the measured one; measured number inside the range.
By their numbers in this assay, from the lowest: compound 3; then compounds 4 and 1 (each within the scatter of the next); then compound 2.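

In this assay, 1,3-benzothiazol-2-yl on this sulfur does not match 1H-benzimidazol-2-yl (a 2.7-fold higher number from compound 3 to compound 4 (0.43 log units; beyond the scatter)), so the two groups are not interchangeable here, though 1,3-benzothiazol-2-yl still improves on 1H-imidazol-2-yl (a 6.3-fold lower number from compound 2 to compound 4 (0.80 log units; beyond the scatter)). The ((pyridin-2-yl)methyl)amino group of compound 1 leaves the number within the scatter of hydrogen (a 1.3-fold lower number from compound 1 to compound 4 (0.10 log units; within the scatter)). No measurement to hand accounts for the gap between the two groups on sulfur. As far as these compounds go, whether 1,3-benzoxazol-2-yl on this sulfur, or a carboxylic acid on the aromatic carbon that carries the ((pyridin-2-yl)methyl)amino group in compound 1, would shift the number remains open.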